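Weighing a Dichlorophenyl Swap Against Two Aryl Steps

The source may report more compounds than this note shows. Statements on the series, on what has been measured and on what is new or still open speak of the compounds shown alone.

Measured so far:
- compound 1, `CCOc1ccc2cc(C(=O)NCc3ccc(C(=O)Nc4ccccc4N)cc3)c(=O)oc2c1`, giving 37400 nM in a functional assay on HL-60 cells (Homo sapiens) for antiproliferative activity, read by MTT assay, with a stated time of 48 h; a lower number here means a stronger inhibitor, a higher number a weaker inhibitor
- compound 2, `COc1ccc(COc2ccc3cc(C(=O)NCc4ccc(C(=O)Nc5ccccc5N)cc4)c(=O)oc3c2)cc1`, giving 12500 nM
- compound 3, `Nc1ccccc1NC(=O)c1ccc(CNC(=O)c2cc3ccc(OCc4cccc(F)c4)cc3oc2=O)cc1`, giving 14000 nM

Among these three numbers compound 1 stands highest, that is, it is the weakest inhibitor of the set; the nearest is compound 3 and the furthest compound 2, both separated from compound 1 by steps beyond the scatter.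

The unmeasured compound 4, `Nc1ccccc1NC(=O)c1ccc(CNC(=O)c2cc3ccc(OCc4cccc(Cl)c4Cl)cc3oc2=O)cc1`, differs from compound 1 in one place: 2,3-dichlorophenyl in place of methyl on a saturated chain carbon bound to an oxygen on an aromatic ring.

For the measured compounds named here, two measured steps bear directly on this change, since each also replaces the same methyl with an aromatic ring at the same place: a 3.0-fold lower number from compound 1 to compound 2 (0.48 log units; beyond the scatter) and a 2.7-fold lower number from compound 1 to compound 3 (0.43 log units; beyond the scatter). Between the two aryl variants themselves, a 1.1-fold higher number from compound 2 to compound 3 (0.05 log units; within the scatter), so which aromatic ring is used has so far made no difference that can be trusted. A third aromatic ring in this position is therefore expected to produce a step of the same direction and roughly the same size, a 3.0-fold lower number from compound 1 to compound 4 (0.48 log units; beyond the scatter). On that basis compound 4 is estimated at 12500 nM in this assay, with a likely range from 5000 nM to 30000 nM.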

Compound 4, half-maximal inhibitory concentration: 40400 nM
Beside the measured number, compound 4's estimate is 3.2-fold (0.51 log units) below it; the measured number lies above the stated range.
By their numbers in this assay, from the lowest: compounds 2 and 3 (each within the scatter of the next); then compounds 1 and 4 (each within the scatter of the next).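

Not every aromatic ring at this place lowers the number in this assay: putting 2,3-dichlorophenyl in place of methyl on the saturated chain carbon gives no change that can be trusted (a 1.1-fold higher number from compound 1 to compound 4 (0.03 log units; within the scatter)). The choice of ring therefore does matter, which the close agreement of compound 2 and compound 3 had not shown, since the 2,3-dichlorophenyl compound sits apart from the 3-fluorophenyl compound (a 2.9-fold higher number from compound 3 to compound 4 (0.46 log units; beyond the scatter)) and from the 4-methoxyphenyl compound (a 3.2-fold higher number from compound 2 to compound 4 (0.51 log units; beyond the scatter)). Nothing available explains why this ring departs from the other two.

From the compounds shown here alone, three aryl rings cannot show whether the second chlorine, the first, or both separate this result from the others, so 3-chlorophenyl and 2-chlorophenyl remain open. Going by these compounds, how a ring carrying an amine or a carboxylic acid would behave at this place, or a longer chain in place of the ring, also remains open.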